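Shortening the amide chain on a macrolide side arm

The source may report more compounds than this note shows. Statements on the series, on what has been measured and on what is new or still open speak of the compounds shown alone.

Three measured compounds share one core and differ only in the group on the amide carbonyl of the side arm. Compound 1 `CC[C@H]1OC(=O)[C@H](C)[C@@H](O[C@H]2C[C@@](C)(OC)[C@@H](O)[C@H](C)O2)[C@H](C)[C@@H](O[C@@H]2O[C@H](C)C[C@H](N(C)C)[C@H]2O)[C@](C)(O)C[C@@H](C)CN(C)[C@H](C)[C@@H](OCCCNC(=O)C2CCC2)[C@]1(C)O` carries a cyclobutyl group there, and in a physicochemical assay for lipophilicity, read by HPLC, measured as chromatographic lipophilicity, at pH 7.4 (on this read-out lower numbers stand for lower lipophilicity and higher numbers for higher lipophilicity), compound 1 gives 3.5. Compound 2 `CCC(=O)NCCCO[C@H]1[C@H](O[C@@H]2[C@@H](C)[C@H](O[C@H]3C[C@@](C)(OC)[C@@H](O)[C@H](C)O3)[C@@H](C)C(=O)O[C@H](CC)[C@@](C)(O)[C@H](O)[C@@H](C)N(C)C[C@H](C)C[C@@]2(C)O)O[C@H](C)C[C@@H]1N(C)C` carries an ethyl group, and in this assay compound 2 gives 2.7. Compound 3 `CCCCCCCC(=O)NCCCO[C@@H]1[C@@H](C)N(C)C[C@H](C)C[C@@](C)(O)[C@H](O[C@@H]2O[C@H](C)C[C@H](N(C)C)[C@H]2O)[C@@H](C)[C@H](O[C@H]2C[C@@](C)(OC)[C@@H](O)[C@H](C)O2)[C@@H](C)C(=O)O[C@H](CC)[C@@]1(C)O` carries a heptyl group, and in this assay compound 3 gives 5.18, the highest of the three numbers, beyond the scatter from both compound 1 and compound 2. Among the measured compounds shown here, the one measured step that bears on the new compound is a number 1.68 log units higher from compound 1 to compound 3 (beyond the scatter), a large rise with the longer chain. Compound 4 `CC[C@H]1OC(=O)[C@H](C)[C@@H](O[C@H]2C[C@@](C)(OC)[C@@H](O)[C@H](C)O2)[C@H](C)[C@@H](O[C@@H]2O[C@H](C)C[C@H](N(C)C)[C@H]2O)[C@](C)(O)C[C@@H](C)CN(C)[C@H](C)[C@@H](OCCCNC(C)=O)[C@]1(C)O` differs from compound 3 in one place: hydrogen in place of hexyl on a saturated chain carbon bound to a carbonyl carbon. Compound 2 gives 2.7 with an ethyl group on the carbonyl, so the shorter acetyl of compound 4 is expected to sit a little lower still. Compound 4 is therefore expected to give 2.3, within a range from 1.8 to 2.8. This estimate means an expected step of a number 2.88 log units lower from compound 3 to compound 4 (beyond the scatter).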

Compound 4, distribution coefficient: 2.41
The estimate for compound 4 lay 0.11 log units below the measured number; the measured number falls inside the stated range.
By their numbers in this assay, from the lowest: compounds 4 and 2 (each within the scatter of the next); then compound 1; then compound 3.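

In this assay the change from heptyl to methyl on the carbonyl carbon brings a number 2.77 log units lower from compound 3 to compound 4 (beyond the scatter) and methyl in place of cyclobutyl brings a number 1.09 log units lower from compound 1 to compound 4 (beyond the scatter) so both of the larger groups now stand well apart from methyl. Yet compound 4 at 2.41 and compound 2 at 2.7 lie within the scatter of each other, so methyl and ethyl on the carbonyl carbon cannot be told apart on this read-out. Nothing in the data gives a reason for the size of these steps.

The compounds shown carry only hydrocarbon groups on the carbonyl carbon, so it stays open how an amine, a carboxylic acid or a phenyl ring there would read. Also open, as far as these compounds go, is whether the numbers keep rising with a chain longer than heptyl, and how a branched chain compares with a straight one.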